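Anilino variation on the shared core: compound 2 to compound 3

This account rests on a few compounds, and the source may have more. Where it says the series, first, only, none or still open, it means among the compounds named here.

Measured so far:
- compound 1 `O=C(CSc1nc(Nc2ccccc2)c2ccccc2n1)Nc1ccccc1F`: 10700 nM
- compound 2 `C=CC(=O)Nc1cccc(NC(=O)CSc2nc(Nc3ccccc3C)c3ccccc3n2)c1`: 30200 nM

For the measured compounds named here, in a functional assay on MGC-803 cells (Homo sapiens) for inhibition, read by MTT assay, with a stated time of 72 h (on this read-out lower numbers stand for stronger inhibition and higher numbers for weaker inhibition), compound 2 gives 30200 nM, the higher of the two numbers known; compound 1 gives 10700 nM, and that gap lies beyond the usual scatter. Compound 3 `C=CC(=O)Nc1cccc(NC(=O)CSc2nc(Nc3ccc(F)c(Cl)c3)c3ccccc3n2)c1` differs from compound 2 by 3-chloro-4-fluorophenyl in place of 2-methylphenyl on a nitrogen on an aromatic ring. Going by the values given here, no step between measured compounds bears on this change, so the expected step of a 2.0-fold lower number from compound 2 to compound 3 (0.30 log units; within the scatter) is small, towards a lower number, and close to the scatter. Compound 3 is estimated at 15000 nM, between 5000 nM and 45000 nM.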

Compound 3, half-maximal inhibitory concentration: 7850 nM
Estimate against measurement, compound 3: 1.9-fold (0.28 log units) above; the range from low to high includes it.
By their numbers in this assay, from the lowest: compounds 3 and 1 (each within the scatter of the next); then compound 2.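

In this assay, the position on the anilino nitrogen proves sensitive to the aryl group it carries: 3-chloro-4-fluorophenyl in place of 2-methylphenyl gives a 3.8-fold lower number from compound 2 to compound 3 (0.59 log units; beyond the scatter). For the compounds shown here, this is the first one-place step, modest in size, with the rest of the structure unchanged. Nothing on hand explains the step.

Whether the chlorine or the fluorine alone accounts for the step stays open, as does the role of removing the methyl group. On these data alone, how a methoxy group or an amine on this phenyl ring would read also remains open.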